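Phenyl to naphthalen-1-yl on the amine nitrogen

The source may hold more compounds than are shown below. What is called first, only, known or untested is meant among the compounds shown, and "the series" means these compounds.

In a functional assay on HT-29 cells (Homo sapiens) for cytotoxicity, read by sulforhodamine B assay (a higher number here means a weaker inhibitor, a lower number a stronger inhibitor), compound 1 `C=C1[C@@H](OC(C)=O)C[C@@H]2[C@](C)(CO[Si](C)(C)C(C)(C)C)[C@H](OC(C)=O)CC[C@@]2(C)[C@@H]1C[C@@H](Nc1ccc(OC)c(OC)c1)C1=CCOC1=O` gives 5330 nM and compound 2 `C=C1[C@@H](OC(C)=O)C[C@@H]2[C@](C)(CO[Si](C)(C)C(C)(C)C)[C@H](OC(C)=O)CC[C@@]2(C)[C@@H]1C[C@@H](Nc1ccccc1)C1=CCOC1=O` gives 4050 nM, so these two stand within the scatter of each other. Compound 3 `C=C1[C@@H](OC(C)=O)C[C@@H]2[C@](C)(CO[Si](C)(C)C(C)(C)C)[C@H](OC(C)=O)CC[C@@]2(C)[C@@H]1C[C@@H](Nc1cccc2ccccc12)C1=CCOC1=O` has naphthalen-1-yl in place of phenyl on an amine nitrogen. For the measured compounds named here, the only measured step at this nitrogen, a 1.3-fold lower number from compound 1 to compound 2 (0.12 log units; within the scatter), lies within the scatter, and it does not enlarge the aromatic ring system, so it gives no direction here. No shift beyond the scatter is expected in this assay, and the expected step is a 1.1-fold lower number from compound 2 to compound 3 (0.03 log units; within the scatter). For compound 3 the estimate is 3800 nM, with an expected range of 1800 nM to 8000 nM.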

Compound 3, half-maximal inhibitory concentration: 15000 nM
For compound 3 the middle estimate is 3.9-fold (0.60 log units) below the measured one; the whole stated range lies below it.
By their numbers in this assay, from the lowest: compounds 2 and 1 (each within the scatter of the next); then compound 3.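

In this assay the group on the amine nitrogen can move the number beyond the scatter, with a 3.7-fold higher number from compound 2 to compound 3 (0.57 log units; beyond the scatter) and a 2.8-fold higher number from compound 1 to compound 3 (0.45 log units; beyond the scatter) for naphthalen-1-yl. Phenyl and 3,4-dimethoxyphenyl had read alike, so the second six-membered aromatic ring of naphthalen-1-yl marks the first weakening seen at this nitrogen. Nothing available explains this step. Open, as far as these compounds go, is whether naphthalen-2-yl or benzyl on this nitrogen reads like phenyl or like naphthalen-1-yl. Also open, from the compounds shown here alone, is whether the step persists with a free hydroxymethyl group in place of the silyl ether on the shared core.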